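Notes on alkylating the amine of compound 3

This account rests on a few compounds, and the source may have more. Where it says the series, first, only, none or still open, it means among the compounds named here.

Compound 1 `Fc1cc(-c2csc(NCC3CCOCC3)n2)c(Cl)cn1` carries fluoro on an aromatic carbon of the shared core. In a functional assay on MV4-11 cells (Homo sapiens) for antiproliferative activity, read by CellTiter-Glo, with a stated time of 72 h (on this read-out lower numbers stand for stronger inhibition of growth and higher numbers for weaker inhibition of growth), compound 1 gives a limit rather than a number, > 10000 nM. Compound 2 `COCCNc1cc(-c2csc(NCC3CCOCC3)n2)c(Cl)cn1` carries (2-methoxyethyl)amino in that place, and in this assay compound 2 likewise gives a limit, > 10000 nM. Between them stands a step that the two limits leave unreadable from compound 1 to compound 2. Going by the values given here, compound 3 `N[C@H]1CC[C@H](Nc2cc(-c3csc(NCC4CCOCC4)n3)c(Cl)cn2)CC1` carries (4-aminocyclohexyl)amino there, and in this assay compound 3 gives 140 nM, the only number in the set, since (the limit of > 10000 nM in this assay, at which 2 of the 3 values shown sit). The gain is an at least 71-fold lower number from compound 1 to compound 3 (1.85 log units; beyond the scatter) and an at least 71-fold lower number from compound 2 to compound 3 (1.85 log units; beyond the scatter), so the (4-aminocyclohexyl)amino group is what separates compound 3 from the two limits.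

Compound 4 `COC[C@H](C)N[C@H]1CC[C@H](Nc2cc(-c3csc(NCC4CCOCC4)n3)c(Cl)cn2)CC1` differs from compound 3 by 1-(methoxymethyl)ethyl in place of hydrogen on an amine nitrogen. Among the compounds with values here, no measured step touches this amine nitrogen; both readable steps concern the group on the aromatic carbon and both end at compound 3, so they fix the starting point but not the direction of this change. The amine remains in place and is only substituted, so in this assay a small step is expected, a 1.4-fold higher number from compound 3 to compound 4 (0.15 log units; within the scatter), within or close to the scatter and of uncertain sign. Compound 4 is therefore estimated at 200 nM, with a range of 60 nM to 700 nM.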

Compound 4, concentration for 50% growth inhibition: 440 nM
For compound 4 the middle estimate is 2.2-fold (0.34 log units) below the measured one; the measured number falls inside the stated range.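

Going by these compounds alone, this is the first reading at the amine nitrogen of the (4-aminocyclohexyl)amino group, since the earlier steps all concerned the group on the aromatic carbon. In this assay, 1-(methoxymethyl)ethyl in place of hydrogen on this nitrogen gives a 3.1-fold higher number from compound 3 to compound 4 (0.50 log units; beyond the scatter) and so costs a modest but real amount of growth inhibition, while compound 4 still gives a number, 440 nM and not a limit, so the hydrogen on this nitrogen is not needed for a readable value in this assay. The measurements shown give no reason for the size or direction of this step.

The compounds shown leave open whether the step belongs to the ether oxygen of the entering group, to its branching or to its defined stereocentre, and whether any substituent on this nitrogen would cost as much. A simple methyl or ethyl group, an unbranched 2-methoxyethyl chain, or the opposite stereocentre of 1-(methoxymethyl)ethyl on this amine nitrogen would each bear on that question.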